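Shortening the side chain on the amino-acid carbon

The compounds below may be only part of what the source reports. "The series", "measured", "known", "first", "only" and "open" are said of these compounds alone.

Measured compounds in a functional assay on the whole organism (Ear, strain ICR) for inhibition, with Mus musculus as the target, with stated times of 30 min and 2 h, at a dose of 10 umol/kg by the oral route; on this read-out lower numbers stand for less inhibition and higher numbers for more inhibition at the one dose given (going by the name of the read-out):
compound 1 `CC[C@H](C)[C@H](NCCC1OCC(C)(C)CO1)C(=O)N[C@H]1[C@@H](OCc2ccccc2)O[C@H](COCc2ccccc2)[C@@H](OCc2ccccc2)[C@@H]1OCc1ccccc1`: 81.6%
compound 2 `CC(C)[C@H](NCCC1OCC(C)(C)CO1)C(=O)N[C@H]1[C@@H](OCc2ccccc2)O[C@H](COCc2ccccc2)[C@@H](OCc2ccccc2)[C@@H]1OCc1ccccc1`: 86.2%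

Compound 2 sits with compound 1 within the usual scatter, as the step of a number 4.6 percentage points higher from compound 1 to compound 2 (within the scatter) shows. Compound 3 `C[C@H](NCCC1OCC(C)(C)CO1)C(=O)N[C@H]1[C@@H](OCc2ccccc2)O[C@H](COCc2ccccc2)[C@@H](OCc2ccccc2)[C@@H]1OCc1ccccc1` differs from compound 2 by methyl in place of isopropyl on a saturated chain carbon bound to an amine nitrogen and a carbonyl carbon. Within the data shown here, the only measured step bearing on this site, a number 4.6 percentage points higher from compound 1 to compound 2 (within the scatter), also removed one carbon from the same chain carbon and stayed within the scatter, so no change beyond the scatter is expected for compound 3 in this assay, with a slight allowance downward for the larger loss. Compound 3 is estimated at 80%, in the range 65% to 92%, a step of a number 6.2 percentage points lower from compound 2 to compound 3 (within the scatter) being expected.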

Compound 3, a percentage reported as inhibition, in the whole organism at one dose (the size of the read-out at that dose, not a potency): 90.3%
Estimate against measurement, compound 3: 10.3 percentage points below, within the range that was stated.
By their numbers in this assay, from the lowest: compounds 1, 2 and 3 (each within the scatter of the next).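

In this assay, methyl in place of isopropyl on a saturated chain carbon bound to an amine nitrogen and a carbonyl carbon gives a number 4.1 percentage points higher from compound 2 to compound 3 (within the scatter), and methyl in place of sec-butyl gives a number 8.7 percentage points higher from compound 1 to compound 3 (within the scatter). At this one dose, sec-butyl, isopropyl and methyl therefore do not separate at this position, and even the widest change in the set stays within the scatter. Nothing on hand explains this result. Still open, going by these compounds, is whether a plain hydrogen on this carbon, or a side chain carrying a carboxylic acid or an amine, gives a read-out outside this band.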